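The source may report more compounds than this note shows. Statements on the series, on what has been measured and on what is new or still open speak of the compounds shown alone.

Compound 1 `CCCN1CC[C@@]2(OC)OC(N)=C(C#N)[C@@H](c3ccc(Cl)cc3Cl)[C@@H]2C1` is the anchor of this small set. In a functional assay on trachea (Cavia porcellus) (a higher number here means a weaker inhibitor, a lower number a stronger inhibitor), compound 1 gives 35500 nM. Compound 2 `CO[C@@]12CCN(Cc3ccccc3)C[C@H]1[C@H](c1ccc(Cl)cc1Cl)C(C#N)=C(N)O2` carries one alteration, (phenyl in place of ethyl on a saturated chain carbon bound to an amine nitrogen in a ring). In this assay compound 2 gives 18300 nM, and the step of a 1.9-fold lower number from compound 1 to compound 2 (0.29 log units; within the scatter) is of a size that repeated measurement of one and the same substance could have produced on its own. Compound 3 `CCCN1CC[C@@]2(OC)OC(N)=C(C#N)[C@@H](c3ccc(F)cc3)[C@@H]2C1` differs from compound 1 in a different part of the molecule, (4-fluorophenyl in place of 2,4-dichlorophenyl on a saturated ring carbon). In this assay compound 3 gives 29600 nM, so the step of a 1.2-fold lower number from compound 1 to compound 3 (0.08 log units; within the scatter) also stays inside the usual spread, and the numbers of compound 2 and compound 3 lie within that spread of each other as well.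

Compound 4 `CO[C@@]12CCN(Cc3ccccc3)C[C@H]1[C@H](c1ccc(F)cc1)C(C#N)=C(N)O2` has not yet been measured. It stands to compound 3 exactly as compound 2 stands to compound 1: phenyl in place of ethyl on a saturated chain carbon bound to an amine nitrogen in a ring. The change is made in two pairs here, at a place described in the same words in both, while the two cores differ by 4-fluorophenyl in place of 2,4-dichlorophenyl on a saturated ring carbon. Going by the values given here, the only guide to what the change does is a 1.9-fold lower number from compound 1 to compound 2 (0.29 log units; within the scatter), which was small. The expected step is a 1.9-fold lower number from compound 3 to compound 4 (0.27 log units; within the scatter), resting on that earlier result alone. On that basis compound 4 is estimated at 16000 nM, with a likely range from 7000 nM to 35000 nM.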

Compound 4, half-maximal inhibitory concentration: 17200 nM
Compound 4: middle estimate off by 1.1-fold (0.03 log units), on the low side; the range from low to high includes it.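

In this assay, replacing propyl with benzyl on the amine nitrogen in the ring gives a 1.7-fold lower number from compound 3 to compound 4 (0.24 log units; within the scatter), and this closely matches what the same change does on the other core: the same change on two cores in this assay, a 1.9-fold lower number (0.29 log units; within the scatter) from compound 1 to compound 2 and a 1.7-fold lower number (0.24 log units; within the scatter) from compound 3 to compound 4, 1.1-fold (0.05 log units) apart, within the scatter of two such steps

The second change, 4-fluorophenyl in place of 2,4-dichlorophenyl, gives a 1.1-fold lower number from compound 2 to compound 4 (0.03 log units; within the scatter) and also repeats across the two cores: the same change on two cores in this assay, a 1.2-fold lower number (0.08 log units; within the scatter) from compound 1 to compound 3 and a 1.1-fold lower number (0.03 log units; within the scatter) from compound 2 to compound 4, 1.1-fold (0.05 log units) apart, within the scatter of two such steps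

This shows that, for these four compounds, neither change moved the number beyond what repeated measurement could produce on either core, but it does not show that either change has a real effect or that the two changes add up, since steps this small cannot be told apart from scatter, and two cores are too few to establish a general rule for the series.

The compounds shown leave open whether a clearly larger step would appear with other groups at these two places, such as a longer chain like hexyl or a carboxylic acid on the chain in place of propyl or benzyl, or a pyridine ring in place of 4-fluorophenyl. They also leave open whether the agreement between the cores would hold for a change that does move the number beyond the scatter.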